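One More Fluoro on Compound 2

This account rests on a few compounds, and the source may have more. Where it says the series, first, only, none or still open, it means among the compounds named here.

Of the compounds shown here, three sharing one core have been tested in an ADME assay on MT4 cells (Homo sapiens) for cytotoxicity, read by MTT assay, with a stated time of 5 days; on this read-out higher numbers stand for lower toxicity in this test and lower numbers for higher toxicity in this test. Compound 1 `N#Cc1ccc(Nc2nccc([C@H](O)c3ccc(-c4ccc(C#N)cc4)cc3F)n2)cc1` gives 30000 nM. Compound 2 `N#Cc1ccc(Nc2nccc([C@@H](O)c3ccc(-c4ccc(C#N)cc4)cc3F)n2)cc1` gives 7500 nM, and compound 3 `N#Cc1ccc(Nc2nccc([C@@H](O)c3ccc(-c4ccc(C#N)cc4)cc3C(F)(F)F)n2)cc1` gives 9780 nM. Compound 2 therefore stands clearly below compound 1 and level with compound 3 on these numbers. The larger gap is a 4.0-fold lower number from compound 1 to compound 2 (0.60 log units; beyond the scatter), and what lies behind it is the fact that compounds 1 and 2 differ only in the configuration as drawn.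

The next compound to be measured is compound 4 `N#Cc1ccc(Nc2nccc([C@@H](O)c3c(F)cc(-c4ccc(C#N)cc4)cc3F)n2)cc1`. It differs from compound 2 by a single change: fluoro in place of hydrogen on an aromatic carbon. In plain terms, this is fluoro in place of hydrogen on an aromatic carbon.

For the measured compounds named here, no measured step makes this exact swap. The closest is a 1.3-fold higher number from compound 2 to compound 3 (0.12 log units; within the scatter), where trifluoromethyl replaces fluoro on an aromatic carbon, and that step stays within the scatter. The larger step between compound 1 and compound 2 concerns only configuration, so it offers little guide to adding a group. No shift beyond the scatter is therefore expected in this assay.

The expected move is small, an estimated 1.2-fold higher number from compound 2 to compound 4 (0.08 log units; within the scatter).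

For compound 4 the estimated value is 9000 nM, with an expected range from 4500 nM to 20000 nM.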

Compound 4, half-maximal cytotoxic concentration: 8400 nM
The estimate for compound 4 lay 1.1-fold (0.03 log units) above the measured number, within the range that was stated.
By their numbers in this assay, from the lowest: compounds 2, 4 and 3 (each within the scatter of the next); then compound 1.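

In this assay, the new fluoro sits on an aromatic carbon of a ring that already carries one fluoro group, ortho to a large group, meta to a 4-cyanophenyl group and meta to a fluoro group, and the result is a 1.1-fold higher number from compound 2 to compound 4 (0.05 log units; within the scatter). For the compounds shown here, until now, the only change measured on this ring was trifluoromethyl in place of fluoro in compound 3, so compound 4 is the first case here in which a group enters at a carbon that held only hydrogen. At this one carbon, then, a single added fluoro leaves the cytotoxicity reading of compound 4 level with that of compound 2.

The compounds shown leave open whether a chlorine atom, a methoxy group or an amine at this same carbon would also stay level with compound 2, and whether this added fluoro would do the same on the configuration drawn in compound 1. The only background fact available concerns configuration, and it offers no explanation for this step.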